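From fluoro to chloro on compound 2

This account rests on a few compounds, and the source may have more. Where it says the series, first, only, none or still open, it means among the compounds named here.

In a functional assay on HeLa cells (Homo sapiens) for cytotoxicity, read by sulforhodamine B assay (on this read-out lower numbers stand for stronger inhibition and higher numbers for weaker inhibition), compound 1 (`CC(C)C(NS(=O)(=O)c1ccc(Cl)cc1)C1=CC(=O)c2c(O)ccc(O)c2C1=O`) gives 8650 nM and compound 2 (`CC(NS(=O)(=O)c1ccc(F)cc1)C1=CC(=O)c2c(O)ccc(O)c2C1=O`) gives 6410 nM. Among the compounds with values here, these two numbers lie within the usual scatter of each other, so compound 2 stands level with the only other measured compound. Compound 3 (`CC(NS(=O)(=O)c1ccc(Cl)cc1)C1=CC(=O)c2c(O)ccc(O)c2C1=O`) has chloro in place of fluoro on an aromatic carbon of compound 2 (chloro in place of fluoro on an aromatic carbon). Compound 1 already carries 4-chlorophenyl and sits within that scatter of compound 2, so no step beyond the scatter is expected in this assay. The expected change is small (a 1.1-fold higher number from compound 2 to compound 3 (0.04 log units; within the scatter)). Compound 3 is estimated at 7000 nM (expected range 3500 nM to 14000 nM).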

Compound 3, half-maximal inhibitory concentration: 810 nM
Estimate against measurement, compound 3: 8.6-fold (0.94 log units) above, and the stated range ends above it.
By their numbers in this assay, from the lowest: compound 3; then compounds 2 and 1 (each within the scatter of the next).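

In this assay, chloro in place of fluoro on this aromatic carbon is not a neutral swap when the chain carries methyl: it gives a 7.9-fold lower number from compound 2 to compound 3 (0.90 log units; beyond the scatter). The chain position also matters when the ring carries chloro, since methyl in place of isopropyl gives an 11-fold lower number from compound 1 to compound 3 (1.03 log units; beyond the scatter). Nothing measured here explains either step. Going by these compounds, whether bromo or methoxy on the same aromatic carbon would match chloro remains open. So does whether an ethyl group on the chain would keep the number of compound 3.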